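One Amino Substitution, Tried on a Second Core

This account rests on a few compounds, and the source may have more. Where it says the series, first, only, none or still open, it means among the compounds named here.

Three compounds have so far been measured in a functional assay on HOP-92 cells (Homo sapiens) for cytotoxicity, read by sulforhodamine B assay, with a stated time of 48 h; on this read-out lower numbers stand for stronger inhibition of growth and higher numbers for weaker inhibition of growth:

compound 1, `ClCc1ccc(Cn2cnc3c(Cl)ncnc32)cc1`: 6020 nM
compound 2, `Nc1nc(Cl)c2ncn(Cc3ccc(CCl)cc3)c2n1`: 1660 nM
compound 3, `ClCc1ccccc1Cn1cnc2c(Cl)ncnc21`: 1480 nM

Compound 1 and compound 2 share a core and differ in one place: amino in place of hydrogen on an aromatic carbon. That single change brought a 3.6-fold lower number from compound 1 to compound 2 (0.56 log units; beyond the scatter).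

Compound 3 is built from the same atoms as compound 1, joined differently; the difference between the two cores is not broken down here. In this assay compound 3 gives a number within the scatter of compound 2, and lower than compound 1 by a margin beyond the scatter.

Compound 4, `Nc1nc(Cl)c2ncn(Cc3ccccc3CCl)c2n1`, has not yet been measured. It differs from compound 3 exactly as compound 2 differs from compound 1, at the same place: amino in place of hydrogen on an aromatic carbon. For the measured compounds named here, only one earlier instance of this change is known, so the expectation rests on that alone: a step of a 2.1-fold lower number from compound 3 to compound 4 (0.33 log units; beyond the scatter) is expected, somewhat smaller than before because compound 3 already gives 1480 nM. Compound 4 is therefore estimated at 700 nM, expected to fall between 250 nM and 2000 nM.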

Compound 4, concentration for 50% growth inhibition: 6460 nM
Compound 4: middle estimate off by 9.2-fold (0.97 log units), on the low side; measured number outside the range, above it.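

On the second core, amino in place of hydrogen on an aromatic carbon brought a 4.4-fold higher number from compound 3 to compound 4 (0.64 log units; beyond the scatter) in this assay, the opposite direction to its step on the first core. The step measured on one core therefore did not carry over to the other, and the two results clearly disagree: the same change on two cores in this assay, a 3.6-fold lower number (0.56 log units; beyond the scatter) from compound 1 to compound 2 and a 4.4-fold higher number (0.64 log units; beyond the scatter) from compound 3 to compound 4, 16-fold (1.20 log units) apart, beyond the scatter of two such steps. This shows that, in these two pairs, the outcome of the change depends on the core that carries it, but it does not show what in the two cores produces the reversal, nor which direction a further core would follow.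

Still open, on these data alone, is whether this split belongs to the amino group alone, or whether a methylamino group or a hydroxyl group at the same place would also move the numbers in opposite directions on the two cores. Also open, as far as these compounds go, is whether the same reversal would appear in cells other than those tested here.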